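The compounds below may be only part of what the source reports. "The series", "measured", "known", "first", "only" and "open" are said of these compounds alone.

Measured compounds in a physicochemical assay for lipophilicity, at pH 7.4; a lower number here means a more polar compound, a higher number a more lipophilic compound:
compound 1 `Cc1cc(C(=O)NC(C)C)nn1Cc1cc(Cl)ccc1OCc1ccccc1`; compound 2 `Cc1cc(C(=O)Nc2ccccn2)nn1Cc1cc(Cl)ccc1OCc1ccccc1`

In this assay compound 1 gives only a limit, > 3.7. Compound 2 likewise gives only a limit, > 3.7. The step from compound 1 to compound 2, a step that the two limits leave unreadable from compound 1 to compound 2, is therefore unreadable, and the step from compound 2 to compound 3 has to be judged from that; compound 2 sits at the limit of > 3.7 in this assay, at which 2 of the 2 values shown sit.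

Compound 3 `Cc1cc(C(=O)NCc2ccccn2)nn1Cc1cc(Cl)ccc1OCc1ccccc1` differs from compound 2 by (pyridin-2-yl)methyl in place of pyridin-2-yl on an amide-type nitrogen. Among the measured compounds shown here, no measured step bears on this change. For compound 3 an estimate of 3.9 (range 3.4 to 4.4) is made, meaning an expected step that the limit leaves unreadable from compound 2 to compound 3, with a fair chance that this assay again reports only a limit.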

Compound 3, distribution coefficient: > 3.7
Compound 3 ended at the assay's limit; the forecaster's own chance of this, stated with the estimate: 60%; the middle value lies beyond the limit too.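

No step among compound 1, compound 2 and compound 3 can be read, as all three values are limits: the limit of > 3.7 in this assay, at which 3 of the 3 values shown sit.

In this assay the compounds shown leave open the size and direction of any difference among the isopropyl, pyridin-2-yl and (pyridin-2-yl)methyl groups on the amide-type nitrogen.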